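Permeability of compound 3 estimated from two measured analogues

The compounds below may be only part of what the source reports. "The series", "measured", "known", "first", "only" and "open" are said of these compounds alone.

Compound 1 `CNC(=O)c1cc(Oc2ccc3oc(Nc4ccc(C(C)C)cc4)nc3c2)ccn1` gives 10 10^-6 cm/s in an ADME assay on Caco-2 cells (Homo sapiens) for permeability, in the apical to basolateral direction; a lower number here means that the compound crosses the layer more slowly, a higher number that the compound crosses the layer faster. Compound 2 `CNC(=O)c1cc(Oc2ccc3oc(Nc4ccc(OC(F)(F)F)cc4)nc3c2)ccn1` gives 10 10^-6 cm/s in this assay, so the step of no change at the digits printed from compound 1 to compound 2 (within the scatter) stayed within the scatter. Compound 3 `CCN1CCN(c2ccc(Nc3nc4cc(Oc5ccnc(C(=O)NC)c5)ccc4o3)cc2)CC1` differs from compound 2 by 4-ethylpiperazin-1-yl in place of trifluoromethoxy on an aromatic carbon. Among the measured compounds shown here, no measured step bears on this change; the only step seen exchanged one small uncharged group for another. Compound 3 is therefore expected to give 5 10^-6 cm/s in this assay, within 1.5 10^-6 cm/s to 12 10^-6 cm/s. The expected step of a 2.0-fold lower number from compound 2 to compound 3 (0.30 log units; within the scatter) reflects an estimate that may well be beyond the scatter.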

Compound 3, apparent permeability: 10 10^-6 cm/s
Compound 3: the middle estimate sits 2.0-fold (0.30 log units) below what was measured; the measured number falls inside the stated range.
By their numbers in this assay, from the lowest: compounds 1, 2 and 3 (each within the scatter of the next).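

In this assay, placing 4-ethylpiperazin-1-yl on this aromatic carbon in place of trifluoromethoxy gives no change at the digits printed from compound 2 to compound 3 (within the scatter) and in place of isopropyl gives no change at the digits printed from compound 1 to compound 3 (within the scatter) in the same series. The position therefore carries a six-membered non-aromatic ring with 2 hetero atoms as well as the two open groups, and the number stays level across all three. No evidence is available to explain this result. The compounds shown leave open whether a carboxylic acid or a primary amine on this carbon would also leave the number level.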